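The source may hold more compounds than are shown below. What is called first, only, known or untested is meant among the compounds shown, and "the series" means these compounds.

Measured compounds:
Compound 1, `C[C@H](NC(=O)c1c(Cc2cccc(F)c2)sc2c1CCOC2)c1ccc(C(=O)O)cc1`, gives 5.1 nM in a functional assay on CHO/Galpha16 cells for antagonist activity at prostaglandin E2 receptor EP4 subtype (Homo sapiens), read by calcium flux, with a stated time of 15 min; a higher number here means a weaker inhibitor, a lower number a stronger inhibitor.
Compound 2, `C[C@H](NC(=O)c1c(C#Cc2ccc(F)cc2)sc2c1CCOC2)c1ccc(C(=O)O)cc1`, gives 15.8 nM in this assay.

Compound 2 has the higher of the two numbers, so it is the weaker inhibitor of the pair, set apart from compound 1 by the step of a 3.1-fold higher number from compound 1 to compound 2 (0.49 log units; beyond the scatter). Compound 3, `C[C@H](NC(=O)c1c(NC(=O)c2ccc(F)cc2)sc2c1CCOC2)c1ccc(C(=O)O)cc1`, has not been measured yet. It differs from compound 2 in one place: ((4-fluorophenyl)carbonyl)amino in place of 2-(4-fluorophenyl)ethynyl on an aromatic carbon. Going by the values given here, no measured step makes this same exchange. Among the compounds with values here, the only step available, a 3.1-fold higher number from compound 1 to compound 2 (0.49 log units; beyond the scatter), swaps two other groups at that same place, so it bears on the change only loosely, showing that this position tolerates change with a modest shift in number. Compound 3 is therefore estimated at 20 nM in this assay, with a range from 4 nM to 100 nM. That amounts to an expected step of a 1.3-fold higher number from compound 2 to compound 3 (0.10 log units; within the scatter), uncertain in direction.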

Compound 3, half-maximal inhibitory concentration: > 1000 nM
Compound 3 ended at the assay's limit (the forecaster's own chance of this, stated with the estimate: 5%); at least 50-fold (1.69 log units) between middle value and limit.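

Until now this position had only shown a modest shift in number when one group replaced another, but the ((4-fluorophenyl)carbonyl)amino group changes that picture, with an at least 63-fold higher number from compound 2 to compound 3 (1.80 log units; beyond the scatter) and an at least 190-fold higher number from compound 1 to compound 3 (2.29 log units; beyond the scatter). All three compounds carry a fluorinated six-membered aromatic ring at this place, so that ring alone does not keep a compound a strong inhibitor; what joins it to the core matters as well. The value of compound 3 is a limit of the assay and not a number: the limit of > 1000 nM in this assay, at which 1 of the 3 values shown sits.

The compounds shown do not tell whether the amide hydrogen, the carbonyl or the linker as a whole accounts for the loss. A methyl group on the amide nitrogen, or a plain amine or ether linker carrying the same 4-fluorophenyl ring, would begin to separate these possibilities.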